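From Butoxy to Benzyloxy on a Shared Core

The source may hold more compounds than are shown below. What is called first, only, known or untested is meant among the compounds shown, and "the series" means these compounds.

In an ADME assay on KB cells (Homo sapiens) for cytotoxicity (a lower number here means that less compound is needed, a higher number that more compound is needed for the effect), compound 1 (`CCOC(=O)N1[C@@H]2C=C[C@@](OC)(C(=O)c3c2cc(OC)c(OC)c3OCc2ccc(F)cc2)N1C(=O)OCC`) gives 51.8 ug/mL and compound 2 (`CCOC(=O)N1[C@@H]2C=C[C@@](OC)(C(=O)c3c2cc(OC)c(OC)c3OCc2ccc(OC)cc2)N1C(=O)OCC`) gives 63.1 ug/mL while compound 3 (`CCCCOc1c(OC)c(OC)cc2c1C(=O)[C@]1(OC)C=C[C@H]2N(C(=O)OCC)N1C(=O)OCC`) gives 76 ug/mL and so lies within the scatter of both others. Compound 4 (`CCOC(=O)N1[C@@H]2C=C[C@@](OC)(C(=O)c3c2cc(OC)c(OC)c3OCc2ccccc2)N1C(=O)OCC`) differs from compound 3 by phenyl in place of propyl on a saturated chain carbon bound to an oxygen on an aromatic ring as phenyl in place of propyl on a saturated chain carbon bound to an oxygen on an aromatic ring. Two measured steps run the reverse way, with 4-fluorophenyl or 4-methoxyphenyl leaving and propyl entering: a 1.5-fold higher number from compound 1 to compound 3 (0.17 log units; within the scatter) and a 1.2-fold higher number from compound 2 to compound 3 (0.08 log units; within the scatter) are both within the scatter. The step expected here is a 1.3-fold lower number from compound 3 to compound 4 (0.10 log units; within the scatter) and so none beyond the scatter in this assay is anticipated. For compound 4 the estimated value is 60 ug/mL with an expected range from 35 ug/mL to 100 ug/mL overall.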

Compound 4, concentration for half-maximal effect: 215 ug/mL
Compound 4: middle estimate off by 3.6-fold (0.55 log units), on the low side, outside the stated range (above it).
By their numbers in this assay, from the lowest: compounds 1, 2 and 3 (each within the scatter of the next); then compound 4.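

In this assay, going by these compounds alone, the benzyloxy group of compound 4 is the first change at this position to leave the scatter, with a 2.8-fold higher number from compound 3 to compound 4 (0.45 log units; beyond the scatter) against the butoxy group. On the benzyl ring itself, hydrogen in place of methoxy gives a 3.4-fold higher number from compound 2 to compound 4 (0.53 log units; beyond the scatter) and hydrogen in place of fluoro gives a 4.2-fold higher number from compound 1 to compound 4 (0.62 log units; beyond the scatter) while the two substituted benzyl compounds stay within the scatter of each other, so the unsubstituted ring alone stands apart among these four. Nothing at hand offers an explanation for this.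

From the compounds shown here alone, whether a chloro group or an amine on that ring, or a chain longer than butyl, would sit with compound 4 or with the other three stays open.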